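The source may report more compounds than this note shows. Statements on the series, on what has been measured and on what is new or still open speak of the compounds shown alone.

Working notes on the series.

Compound 1 `CCOc1ncc(-c2nc(C(F)(F)F)sc2N2CCN(C(=O)Cn3cnc4cccnc43)[C@H](C)C2)cn1` gives 20 nM in a functional assay on U2OS cells for antagonist activity at C-X-C chemokine receptor type 3 (Homo sapiens), read by beta-arrestin recruitment; on this read-out lower numbers stand for stronger inhibition and higher numbers for weaker inhibition. Compound 2 `CCOc1ncc(-c2nc(C(F)(F)F)sc2N2CCN(C(=O)Cn3ccc4cccnc43)[C@H](C)C2)cn1` gives 47 nM, and compound 3 `CCOc1ncc(-c2nc(C(F)(F)F)sc2N2CCN(C(=O)Cn3nc(C)cc3C)[C@H](C)C2)cn1` gives 87 nM. All three differ only in the group on the saturated chain carbon bound to the carbonyl carbon. The measured steps there are a 2.4-fold higher number from compound 1 to compound 2 (0.37 log units; beyond the scatter) and a 4.4-fold higher number from compound 1 to compound 3 (0.64 log units; beyond the scatter), both beyond the scatter, while a 1.9-fold higher number from compound 2 to compound 3 (0.27 log units; within the scatter) stays within it. Compound 3 thus carries the highest of the three numbers, but its gap to compound 2 is within the scatter, so no order between these two can be read.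

Compound 4 `CCOc1ncc(-c2nc(C(F)(F)F)sc2N2CCN(C(=O)Cn3cc(Cl)cn3)[C@H](C)C2)cn1` carries the change (4-chloro-1H-pyrazol-1-yl in place of 3,5-dimethyl-1H-pyrazol-1-yl on a saturated chain carbon bound to a carbonyl carbon). For the measured compounds named here, none of the measured steps exchanges one five-membered ring with two hetero atoms for another of the same kind; the only step ending at a pyrazole, from compound 2 to compound 3, was within the scatter. For compound 4 no step beyond the scatter in this assay is therefore expected. The expected value for compound 4 is 90 nM, within a range from 40 nM to 200 nM. This corresponds to an estimated step of a 1.0-fold higher number from compound 3 to compound 4 (0.01 log units; within the scatter).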

Compound 4, half-maximal inhibitory concentration: 272 nM
Beside the measured number, compound 4's estimate is 3.0-fold (0.48 log units) below it, and the stated range ends below it.
By their numbers in this assay, from the lowest: compound 1; then compounds 2 and 3 (each within the scatter of the next); then compound 4.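

In this assay the group on the saturated chain carbon bound to a carbonyl carbon separates one pyrazole from another: a 3.1-fold higher number from compound 3 to compound 4 (0.50 log units; beyond the scatter) shows that keeping a five-membered aromatic ring with 2 hetero atoms does not keep the number. Compound 4 stands beyond the scatter of all three earlier compounds, with a 5.8-fold higher number from compound 2 to compound 4 (0.76 log units; beyond the scatter) and a 14-fold higher number from compound 1 to compound 4 (1.13 log units; beyond the scatter) as the wider steps. No measurement at hand bears on the reason for this rise.

From the compounds shown here alone, the chlorine entering and the two methyl groups leaving fall into one step, so the share of each remains open. A 1H-pyrazol-1-yl without substituents or a 4-methyl-1H-pyrazol-1-yl in the same place would divide that step into its two parts.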